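Changing the Benzyl Substituent in a Hydroxamic Acid Series

This account rests on a few compounds, and the source may have more. Where it says the series, first, only, none or still open, it means among the compounds named here.

Measured compounds:
compound 1, `Cc1ccc(CN2CCC(c3noc(COc4ccc(/C=C/C(=O)NO)cc4)n3)CC2)cc1`: 76%
compound 2, `O=C(/C=C/c1ccc(OCc2nc(C3CCN(Cc4ccc(F)c(F)c4)CC3)no2)cc1)NO`: 60%

In an assay on isolated protein for inhibition of protein deacetylase HDAC6 (Homo sapiens), read by fluorescence, with a stated time of 1 h, tested at 100 nM (a lower number here means less inhibition, a higher number more inhibition at the concentration tested (going by the name of the read-out)), compound 1 gives 76% and compound 2 gives 60%. Among the compounds with values here, compound 2 stands lowest of the two measured compounds; the single step on record, a number 16 percentage points lower from compound 1 to compound 2 (beyond the scatter), is beyond the scatter and came from placing 3,4-difluorophenyl where 4-methylphenyl had been on a saturated chain carbon bound to an amine nitrogen in a ring. Compound 3, `N#Cc1ccc(CN2CCC(c3noc(COc4ccc(/C=C/C(=O)NO)cc4)n3)CC2)cc1`, differs from compound 2 at the same place: 4-cyanophenyl in place of 3,4-difluorophenyl on a saturated chain carbon bound to an amine nitrogen in a ring. Within the data shown here, no measured step involves a 4-cyanophenyl group, so the one step available shows only that a change at this position can move the read-out by a modest amount. On that basis the expected step of a number 3 percentage points higher from compound 2 to compound 3 (within the scatter) is small and its direction uncertain. Compound 3 is therefore estimated at 63%, between 42% and 82%.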

Compound 3, a percentage reported as inhibition, at one concentration (the size of the read-out at that concentration, not a potency): 65%
Beside the measured number, compound 3's estimate is 2 percentage points below it, within the range that was stated.
By their numbers in this assay, from the lowest: compounds 2 and 3 (each within the scatter of the next); then compound 1.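

In this assay the change from the difluorinated ring to the nitrile-bearing ring appears as a number 5 percentage points higher from compound 2 to compound 3 (within the scatter) and so 4-cyanophenyl and 3,4-difluorophenyl cannot be told apart at this position. Cyano on the aromatic carbon that carries methyl in compound 1 gives a number 11 percentage points lower from compound 1 to compound 3 (beyond the scatter) and so both replacements of 4-methylphenyl on record, although they differ in their atoms, end up beyond the scatter from compound 1, which has the highest number of the three. Nothing measured here explains why the methyl compound stands apart.

Going by these compounds, whether a plain benzyl group with no ring substituent, or a 4-methoxybenzyl group, would reach the level of compound 1 remains open. So does whether methyl at the 4-position matters in itself, or whether a longer chain there, such as ethyl, would serve equally well.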